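The source may hold more compounds than are shown below. What is called first, only, known or untested is meant among the compounds shown, and "the series" means these compounds.

In an ADME assay on a cell-free system (plasma, Homo sapiens), with a stated time of 30 min (on this read-out lower numbers stand for a less stable compound and higher numbers for a more stable compound), compound 1 `COc1ccccc1C(=O)N[C@]1(OC)C(=O)N2C(C(=O)OCc3cccc(C)c3)=C(CSc3nnnn3CC(=O)O)CO[C@@H]21` reads 11% while compound 2 `COc1ccccc1C(=O)N[C@]1(OC)C(=O)N2C(C(=O)OCc3ccc(C(=O)O)cc3)=C(CSc3nnnn3C)CO[C@@H]21` reads 26% and so stands higher, by a gap beyond the usual scatter. Compound 3 `CCCOc1ccccc1C(=O)N[C@]1(OC)C(=O)N2C(C(=O)OCc3ccc(C(=O)O)cc3)=C(CSc3nnnn3C)CO[C@@H]21` alters compound 2 in one place (ethyl in place of hydrogen on a saturated chain carbon bound to an oxygen on an aromatic ring) with ethyl in place of hydrogen on a saturated chain carbon bound to an oxygen on an aromatic ring, which turns methoxy into propoxy. Among the compounds with values here, no measured pair shows this change, which leaves the expectation loose. No step beyond the scatter is expected in this assay (estimated as a number 2 percentage points lower from compound 2 to compound 3 (within the scatter)). Compound 3 is expected at 24% (estimated range 10% to 42%).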

Compound 3, percent of the compound remaining: 26%
The estimate for compound 3 lay 2 percentage points below the measured number, and the stated range covers the measured number.
By their numbers in this assay, from the lowest: compound 1; then compounds 2 and 3 (each within the scatter of the next).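

In this assay there is no change at the digits printed from compound 2 to compound 3 (within the scatter) when methoxy becomes propoxy. This is the first step shown at this position, and it shows that adding ethyl here keeps the two compounds within the usual scatter of each other. Nothing available explains this result. Still open, as far as these compounds go, is whether a longer chain such as butoxy, or a chain ending in an amine or a carboxylic acid, would also stay within that scatter. One step also cannot show whether the same swap would behave alike on compound 1.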